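From 2-Chlorophenyl to 3-Hydroxyphenyl on a Sulfonyl Sulfur

The source may hold more compounds than are shown below. What is called first, only, known or untested is meant among the compounds shown, and "the series" means these compounds.

Compound 1 (`O=S(=O)(Nc1ccc(-c2nc3ccccc3o2)cc1)c1cccc(F)c1`) gives > 100000 nM in an ADME assay on HEK293 cells (Homo sapiens) for cytotoxicity, read by resazurin assay, with a stated time of 48 h (on this read-out lower numbers stand for higher toxicity in this test and higher numbers for lower toxicity in this test), as a limit of the assay. Compound 2 (`O=S(=O)(Nc1ccc(-c2nc3ccccc3o2)cc1)c1ccccc1Cl`) gives > 100000 nM in this assay and so also stands at a limit rather than at a number. For the measured compounds named here, the only measured step is a step that the two limits leave unreadable from compound 1 to compound 2 and it put 2-chlorophenyl in place of 3-fluorophenyl on a sulfonyl sulfur. Compound 3 (`O=S(=O)(Nc1ccc(-c2nc3ccccc3o2)cc1)c1cccc(O)c1`) now carries 3-hydroxyphenyl in place of 2-chlorophenyl on a sulfonyl sulfur. Going by the values given here, compound 1 and compound 2 share one limit (the limit of > 100000 nM in this assay, at which 2 of the 2 values shown sit) and offer no step of readable size, so no step beyond the scatter is expected in this assay and compound 3 may well report only a limit too. The expected change is a number no higher from compound 2 to compound 3 (the limit leaves the size open) in this estimate. For compound 3 the estimated value is 100000 nM with 40000 nM to 200000 nM as its expected range.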

Compound 3, half-maximal cytotoxic concentration: > 100000 nM
Compound 3: only a limit was reported; the forecaster's own chance of this, stated with the estimate: 75%; the middle value lies on the limit itself.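

Compound 3, like compound 1 and compound 2, reports only a limit in this assay, so no step among these three compounds can be read: the limit of > 100000 nM in this assay, at which 3 of the 3 values shown sit.

The compounds shown leave open where each true value lies, and so whether 3-fluorophenyl, 2-chlorophenyl and 3-hydroxyphenyl on a sulfonyl sulfur differ at all.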